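The source may report more compounds than this note shows. Statements on the series, on what has been measured and on what is new or still open speak of the compounds shown alone.

Measured compounds:
- compound 1 `CCc1cc(Cc2cccc(OC)c2)c(=O)n(CC(=O)Nc2ccc(I)cc2)n1` gives > 50000 nM in an assay on HL-60 cells for agonist activity at N-formyl peptide receptor 3 (Homo sapiens), read by calcium flux; on this read-out higher numbers stand for an effect only at larger amounts of compound and lower numbers for an effect already at smaller amounts; this is a limit of the assay.
- compound 2 `COc1cccc(Cc2cc(C3CCCCC3)nn(CC(=O)Nc3ccc(Br)cc3)c2=O)c1` gives > 50000 nM in this assay; this too is a limit.
- compound 3 `Cc1cc(Cc2cccc(Cl)c2)c(=O)n(CC(=O)Nc2ccc(Br)cc2)n1` gives > 50000 nM in this assay; again a limit, not a number.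

Compound 3 therefore stands at the limit of this assay, with no number of its own, and the same holds for every value shown, as summed up in the limit of > 50000 nM in this assay, at which 3 of the 3 values shown sit. Within the data shown here, no pair of measured compounds differs in one place, so no measured step is available to gauge any change.

Compound 4 `Cc1cc(Cc2ccoc2)c(=O)n(CC(=O)Nc2ccc(Br)cc2)n1` is the untested partner of compound 3. The change is furan-3-yl in place of 3-chlorophenyl on a saturated chain carbon bound to an aromatic carbon. With all three measured values sitting at the limit, nothing in the numbers points to either direction for this change. The step from compound 3 to compound 4 is expected to be none beyond the scatter, written as a step that the limit leaves unreadable from compound 3 to compound 4. Compound 4 is accordingly expected at around 60000 nM, in a range from 20000 nM to 200000 nM, most likely again as a limit rather than a number.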

Compound 4, half-maximal effective concentration: > 50000 nM
Compound 4: no number, only a limit; the forecaster's own chance of this, stated with the estimate: 85%; the middle value lies beyond the limit too.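

Compound 3 and compound 4 both stand at a limit of the assay, so the step from the one to the other cannot be read. The compounds shown leave open what change, if any, would give a number in this assay, since every value sits at one limit: the limit of > 50000 nM in this assay, at which 4 of the 4 values shown sit.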